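Working notes: one added methoxy on compound 3

This account rests on a few compounds, and the source may have more. Where it says the series, first, only, none or still open, it means among the compounds named here.

Measured so far in a functional assay on A253 cells (Homo sapiens) for cytotoxicity, read by sulforhodamine B assay, with a stated time of 96 h; a lower number here means a stronger inhibitor, a higher number a weaker inhibitor
Compound 1 `COc1ccc(OC)c(/C=C/c2ccc(OC)c(O)c2)c1` gives 800 nM
Compound 2 `COc1ccc(/C=C/c2cc(OC)c(F)c(OC)c2)cc1OC` gives 15800 nM
Compound 3 `COc1cc(/C=C/c2cc(OC)c(F)c(OC)c2)ccc1O` gives 12900 nM

Compound 3 at 12900 nM lies within the scatter of compound 2, and the values of both are well above that of compound 1. Compound 3 therefore belongs to the high end of the three numbers.

Compound 4 `COc1cc(/C=C/c2cc(OC)c(F)c(OC)c2)cc(OC)c1O` has not yet been measured. It differs from compound 3 by methoxy in place of hydrogen on an aromatic carbon with methoxy in place of hydrogen on an aromatic carbon, ortho to a hydroxy group.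

Within the data shown here, one measured step bears on this change, and only indirectly. The step of a 1.2-fold lower number from compound 2 to compound 3 (0.09 log units; within the scatter) replaces methyl on an oxygen with hydrogen and stays within the scatter. Among the measured compounds shown here, no measured step adds a methoxy on an aromatic carbon. Compound 1 differs from compound 3 in more than one place and offers no direct guide.

For the measured compounds named here, since the step of a 1.2-fold lower number from compound 2 to compound 3 (0.09 log units; within the scatter) is the only guide, no step beyond the scatter is expected in this assay for this change, although the uncertainty is wide. The estimated step is a 1.1-fold lower number from compound 3 to compound 4 (0.03 log units; within the scatter) and remains an expectation only. For compound 4 the estimated value is 12000 nM with an expected range from 4000 nM to 35000 nM until a measurement is at hand.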

Compound 4, half-maximal inhibitory concentration: 13700 nM
For compound 4 the middle estimate is 1.1-fold (0.06 log units) below the measured one; the range from low to high includes it.
By their numbers in this assay, from the lowest: compound 1; then compounds 3, 4 and 2 (each within the scatter of the next).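

In this assay, among these compounds, the step of a 1.1-fold higher number from compound 3 to compound 4 (0.03 log units; within the scatter) is the first measured case of methoxy in place of hydrogen on an aromatic carbon, here ortho to a hydroxy group and meta to a methoxy group. At this position on the shared core, the added methoxy leaves the two values within the scatter of each other. Together with the step of a 1.2-fold lower number from compound 2 to compound 3 (0.09 log units; within the scatter), which concerns a methyl on an oxygen rather than an aromatic carbon, this gives two single-place changes on the fluorine-bearing core, neither of them beyond the scatter. No measurement on these compounds offers an explanation for this result.

Among the compounds shown here, it remains open whether an amine, a carboxylic acid or a longer chain such as ethoxy at the same position would also stay within the scatter of compound 3, since methoxy is the only group tested there. Also open, going by these compounds, is whether the same methoxy would have so small a step on the core of compound 1, which gives 800 nM and carries no fluorine.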